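4-Fluorophenyl to 4-bromophenyl in the series

This account rests on a few compounds, and the source may have more. Where it says the series, first, only, none or still open, it means among the compounds named here.

Measured in a functional assay on MCF7 cells (Homo sapiens) for inhibition, read by MTT assay, with a stated time of 72 h; a higher number here means a weaker inhibitor, a lower number a stronger inhibitor:
compound 1 `COc1ccc(-c2nnc(SCCCN3CCN(c4nc5ccccc5o4)CC3)o2)cc1`: 52800 nM
compound 2 `Fc1ccc(-c2nnc(SCCCN3CCN(c4nc5ccccc5o4)CC3)o2)cc1`: 52300 nM

Compound 2 gives 52300 nM, which places it level with compound 1 within the scatter. Compound 3 `Brc1ccc(-c2nnc(SCCCN3CCN(c4nc5ccccc5o4)CC3)o2)cc1` is the next case, with bromo in place of fluoro on an aromatic carbon, para to a large group: bromo in place of fluoro on an aromatic carbon. For the measured compounds named here, the one measured step at this place is a 1.0-fold lower number from compound 1 to compound 2 (0.00 log units; within the scatter), with fluoro in place of methoxy, and it lies within the scatter. Going by the values given here, this is thin support, as it is a single step and no bromo compound has been measured. No step beyond the scatter is therefore expected in this assay. Compound 3 is expected at 45000 nM, with an estimated range of 20000 nM to 95000 nM. The estimated step is a 1.2-fold lower number from compound 2 to compound 3 (0.07 log units; within the scatter).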

Compound 3, half-maximal inhibitory concentration: 115000 nM
Estimate against measurement, compound 3: 2.6-fold (0.41 log units) below; measured number above the stated range.
By their numbers in this assay, from the lowest: compounds 2 and 1 (each within the scatter of the next); then compound 3.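

At this position on the aromatic ring, the choice of group does move the number in this assay: bromo in place of fluoro gives a weaker inhibitor (a 2.2-fold higher number from compound 2 to compound 3 (0.34 log units; beyond the scatter)), and bromo in place of methoxy does the same (a 2.2-fold higher number from compound 1 to compound 3 (0.34 log units; beyond the scatter)). The position is therefore not indifferent to its group, as the level pair of compound 1 and compound 2 alone might have suggested, although both new steps are modest and rest on compound 3 alone. No measured property is at hand to account for these steps.

Going by these compounds, it remains open whether chloro would stand level with fluoro or follow bromo. An amine or a carboxylic acid at this position would show whether any group can bring the number clearly below that of compound 2.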